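The source may hold more compounds than are shown below. What is called first, only, known or untested is meant among the compounds shown, and "the series" means these compounds.

Compound 3, `Cn1c(=O)c(S(=O)(=O)Cc2ccc(F)cc2)cc2cnc(Nc3ccc4[nH]ccc4c3)nc21`, gives the highest number of the three measured compounds in a functional assay on K562 cells (Homo sapiens) for inhibition, read by trypan blue exclusion, with a stated time of 72 h (a lower number here means a stronger inhibitor, a higher number a weaker inhibitor), at 30000 nM. Compound 1, `Cn1c(=O)c(S(=O)(=O)c2ccc(F)cc2F)cc2cnc(Nc3ccc4cc[nH]c4c3)nc21`, gives 5000 nM in this assay, and compound 2, `Cn1c(=O)c(S(=O)(=O)c2ccc(F)cc2)cc2cnc(Nc3cccc4[nH]ccc34)nc21`, gives 750 nM; both gaps to compound 3 lie beyond the usual scatter, so compound 3 is the weakest of the three. The step considered here leads to compound 4, `Cc1ccc(S(=O)(=O)c2cc3cnc(Nc4ccc5[nH]ccc5c4)nc3n(C)c2=O)cc1`, which has not been measured in this assay. The difference is 4-methylphenyl in place of 4-fluorobenzyl on a sulfonyl sulfur. In this part of the structure the change brings compound 4 nearer to compounds 1 and 2, whose numbers are lower than that of compound 3, although these compounds also differ elsewhere, so the comparison is not clean. Compound 4 is therefore expected to give a lower number than compound 3, with a step of a 15-fold lower number from compound 3 to compound 4 (1.18 log units; beyond the scatter) that is estimated to lie beyond the scatter. The estimate for compound 4 in this assay is 2000 nM, within a range from 400 nM to 10000 nM.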

Compound 4, half-maximal inhibitory concentration: 750 nM
The estimate for compound 4 lay 2.7-fold (0.43 log units) above the measured number, within the range that was stated.
By their numbers in this assay, from the lowest: compounds 2 and 4 (each within the scatter of the next); then compound 1; then compound 3.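

In this assay, the pair formed by compound 3 and compound 4 ties a large change to the group on the sulfonyl sulfur alone: 4-methylphenyl in place of 4-fluorobenzyl gives a 40-fold lower number from compound 3 to compound 4 (1.60 log units; beyond the scatter), with the rest of the structure the same. The earlier compounds shown here differed from one another in more than one place, so none of their gaps could be assigned to this position. Nothing shown here accounts for the size of the step.

The change swaps benzyl for phenyl and fluorine for methyl at once, and the data do not separate these two parts. Also open, on these data alone, is how the assay would respond to a 4-methylbenzyl group on the sulfonyl sulfur, or to a group carrying an amine or a carboxylic acid there.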